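The source may report more compounds than this note shows. Statements on the series, on what has been measured and on what is new or still open speak of the compounds shown alone.

Working notes on the series. Among the compounds with values here, only two readings are available so far. In a physicochemical assay, read by spectrophotometry, with a stated time of 30 min (on this read-out lower numbers stand for stronger inhibition and higher numbers for weaker inhibition), compound 1 `O=C(CCc1nc2ccccc2c(=O)[nH]1)N/N=C/c1ccc([N+](=O)[O-])cc1` gives 328000000 nM while compound 2 `O=C(CCCc1nc2ccccc2c(=O)[nH]1)N/N=C/c1ccc(Cl)cc1` gives 353000000 nM as its reading. Compound 1 therefore stands level with compound 2 within the scatter, and the two cannot be ranked.

Compound 3 `O=C(CCc1nc2ccccc2c(=O)[nH]1)N/N=C/c1cc(O)c(O)c(O)c1` has not yet been measured. It keeps the rest of compound 1 and carries 3,4,5-trihydroxyphenyl in place of 4-nitrophenyl on a carbon with a double bond to nitrogen. Within the data shown here, the counted difference is 3,4,5-trihydroxyphenyl in place of 4-nitrophenyl on a carbon with a double bond to nitrogen and this is the only change.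

Among the measured compounds shown here, no step between measured compounds is available, so the series offers no direct guide to the size of this change. The expectation rests on the structural change alone. In this assay a step beyond the scatter is expected, toward a lower number and so toward stronger inhibition. The estimate is an 11-fold lower number from compound 1 to compound 3 (1.04 log units; beyond the scatter) and it stays an expectation until the reading exists. For compound 3 the estimated value is 30000000 nM with an expected range from 3000000 nM to 150000000 nM on repeated measurement.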

Compound 3, half-maximal inhibitory concentration: 81000000 nM
For compound 3 the middle estimate is 2.7-fold (0.43 log units) below the measured one; low and high end bracket the measured number.
By their numbers in this assay, from the lowest: compound 3; then compounds 1 and 2 (each within the scatter of the next).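

In this assay, the aryl group on a carbon with a double bond to nitrogen proves to be a place where a single change moves the reading: 3,4,5-trihydroxyphenyl in place of 4-nitrophenyl gives a 4.0-fold lower number from compound 1 to compound 3 (0.61 log units; beyond the scatter). Compounds 1 and 2 could not show this, since they differ in more than one place and their readings stand within the scatter of each other. Within the data shown here, the step is modest and comes with the loss of the nitro group and the entry of hydrogen-bond donors where the leaving group has none, but no measurement on these compounds ties the step to either feature of the change, and none speaks to its origin.

The compounds shown leave open which part of the new group carries the step, since a phenyl ring with a single hydroxyl, or with methoxy groups in place of the hydroxyls, would separate the contribution of each substituent from that of the whole set. Among these compounds, also open is whether the same exchange holds on a longer chain, as the step so far stands on the shorter chain of compound 1 alone.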